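The source may hold more compounds than are shown below. What is called first, only, known or untested is meant among the compounds shown, and "the series" means these compounds.

Compound 1 `CC(C)(C)OC(=O)N1CCN(c2cnc(OCc3ccc(S(C)(=O)=O)cc3)nc2)CC1`: 20%
Compound 2 `C[C@@H]1CN(C(=O)OC(C)(C)C)CCN1c1ncc(OCc2ccc(S(=O)(=O)N(C)C)cc2)cn1`: 39%
Compound 3 `C[C@@H]1CN(C(=O)OC(C)(C)C)CCN1c1ncc(OCc2ccc(C#N)cc2)cn1`: 88%

In a functional assay on isolated protein with Glucose-dependent insulinotropic receptor (Mus musculus) as the target, read by HTRF and cAMP accumulation, with a stated time of 45 min (on this read-out higher numbers stand for larger maximal responses and lower numbers for smaller maximal responses), compound 3 gives 88%, the highest of the three numbers; compound 2 is the nearest and compound 1 the furthest, both beyond the scatter. Compound 4 `C[C@@H]1CN(C(=O)OC(C)(C)C)CCN1c1ncc(OCc2ccc(S(C)(=O)=O)cc2F)cn1` differs from compound 3 in one place: 2-fluoro-4-(methylsulfonyl)phenyl in place of 4-cyanophenyl on a saturated chain carbon bound to an oxygen on an aromatic ring. Within the data shown here, the one step that bears on this exchange is a number 49 percentage points higher from compound 2 to compound 3 (beyond the scatter), a large rise when a cyano replaced a sulfur-bearing group. Compound 1, which carries a methylsulfonyl on this ring, shows the smallest number of the set. Going back from cyano to a methylsulfonyl is therefore expected to lower the response, as an estimated a number 58 percentage points lower from compound 3 to compound 4 (beyond the scatter). For compound 4 the estimated maximal response is 30%, within 12% to 55%.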

Compound 4, intrinsic activity: the largest response reached, in percent of the reference agonist's: 90%
Compound 4: middle estimate off by 60 percentage points, on the low side, outside the stated range (above it).
By their numbers in this assay, from the lowest: compound 1; then compound 2; then compounds 3 and 4 (each within the scatter of the next).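

With 2-fluoro-4-(methylsulfonyl)phenyl in place of 4-cyanophenyl, this assay shows a number 2 percentage points higher from compound 3 to compound 4 (within the scatter), so the nitrile is not needed here for a large maximal response. A ring bearing a methylsulfonyl group can therefore sit on this saturated chain carbon without the response falling. Nothing measured here explains this result. The fluorine and methylsulfonyl groups enter together, so the compounds shown leave their separate contributions open. Also open, going by these compounds, is whether a chlorine in place of the fluorine, or an amide in place of the methylsulfonyl, would keep the response.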